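The source may hold more compounds than are shown below. What is called first, only, known or untested is meant among the compounds shown, and "the series" means these compounds.

Measured in a functional assay on cells (T-cell, Homo sapiens) for inhibition; on this read-out lower numbers stand for stronger inhibition and higher numbers for weaker inhibition:
- compound 1 `COc1ccc(-c2cnc3nc(N)nc(N4CCN(C(=O)c5ccccc5)CC4)c3n2)cc1OC`: 400 nM
- compound 2 `COc1ccc(-c2cnc3nc(N)nc(N4CCN(C(=O)Nc5ccc(C#N)cc5)CC4)c3n2)cc1OC`: 74 nM
- compound 3 `COc1ccc(-c2cnc3nc(N)nc(N4CCN(C(=O)CCc5ccccc5)CC4)c3n2)cc1OC`: 100 nM

Compound 3 stands second highest of the three numbers in this assay. Its nearest neighbour is compound 2, the step of a 1.4-fold higher number from compound 2 to compound 3 (0.13 log units; within the scatter) being within the scatter, so no order between the two can be read. Compound 1 lies furthest away, the step of a 4.0-fold lower number from compound 1 to compound 3 (0.60 log units; beyond the scatter) running beyond the scatter.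

Compound 4 `COc1ccc(-c2cnc3nc(N)nc(N4CCN(C(=O)COc5ccc(Cl)cc5)CC4)c3n2)cc1OC` is not yet measured. Against compound 3 it differs in one place: 4-chlorophenoxy in place of benzyl on a saturated chain carbon bound to a carbonyl carbon.

Going by the values given here, two measured steps bear on this. a 4.0-fold lower number from compound 1 to compound 3 (0.60 log units; beyond the scatter) shows that extending the group on the carbonyl carbon from phenyl to phenethyl gave a modest gain. a 1.4-fold higher number from compound 2 to compound 3 (0.13 log units; within the scatter) shows that the (4-cyanophenyl)amino and phenethyl variants sit together within the scatter. Among the compounds with values here, no measured pair exchanges a chain carbon for an oxygen or introduces a chlorine on the ring, so the change itself is untested here. With the two extended groups sitting close, the step of a 1.2-fold lower number from compound 3 to compound 4 (0.07 log units; within the scatter) is expected to stay within the scatter. Compound 4 is therefore estimated at 85 nM, with a range from 30 nM to 250 nM.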

Compound 4, half-maximal inhibitory concentration: 0.5 nM
Compound 4: the middle estimate sits 170-fold (2.23 log units) above what was measured; measured number below the stated range.
By their numbers in this assay, from the lowest: compound 4; then compounds 2 and 3 (each within the scatter of the next); then compound 1.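

In this assay, going by these compounds alone, the group on this carbonyl carbon proves far more sensitive than the earlier compounds showed: a 200-fold lower number from compound 3 to compound 4 (2.30 log units; beyond the scatter) is a large step, whereas the earlier steps at this place were modest at most. The gain also holds against the other two variants, with a 150-fold lower number from compound 2 to compound 4 (2.17 log units; beyond the scatter) and an 800-fold lower number from compound 1 to compound 4 (2.90 log units; beyond the scatter), so (4-chlorophenoxy)methyl stands apart from phenyl, phenethyl and (4-cyanophenyl)amino here. Nothing available accounts for the size of this gain.

The change brings in a chain oxygen and a ring chlorine together, and the compounds shown do not separate the two; phenoxymethyl and 4-chlorophenethyl would tell them apart. As far as these compounds go, whether the gain survives with fluorine or methoxy in place of the chlorine, or with a longer chain before the oxygen, also stays open.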